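Ortho substitution on the sulfonyl phenyl of the kallikrein-7 series

The source may report more compounds than this note shows. Statements on the series, on what has been measured and on what is new or still open speak of the compounds shown alone.

Three compounds of the shared core have numbers in an assay on isolated protein for inhibition of kallikrein-7 (Mus musculus), read by fluorescence, with stated times of 10 min and 30 min; a higher number here means a weaker inhibitor, a lower number a stronger inhibitor. Compound 1 `CC1=NC(c2cn(S(=O)(=O)c3ccccc3)c3ccc(C)cc23)CN1` carries an unsubstituted phenyl on the sulfonyl sulfur; in this assay compound 1 gives 15000 nM, the highest of the three numbers. Compound 2 `CC1=NC(c2cn(S(=O)(=O)c3cccc(Cl)c3)c3ccc(C)cc23)CN1` gives 10000 nM in this assay, and compound 3 `CC1=NC(c2cn(S(=O)(=O)c3ccccc3Cl)c3ccc(C)cc23)CN1` gives 1500 nM. The step of a 1.5-fold lower number from compound 1 to compound 2 (0.18 log units; within the scatter) stays within the scatter, whereas a 10-fold lower number from compound 1 to compound 3 (1.00 log units; beyond the scatter) and a 6.7-fold lower number from compound 2 to compound 3 (0.82 log units; beyond the scatter) are both modest steps to a lower number.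

Compound 4 `CC1=NC(c2cn(S(=O)(=O)c3ccccc3C)c3ccc(C)cc23)CN1` differs from compound 1 in one place: methyl in place of hydrogen on an aromatic carbon. Going by the values given here, the place is the same one that holds the chloro in compound 3, so the step of a 10-fold lower number from compound 1 to compound 3 (1.00 log units; beyond the scatter) is the closest precedent, with a 6.7-fold lower number from compound 2 to compound 3 (0.82 log units; beyond the scatter) showing that this place, rather than the one occupied in compound 2, is where the lowering appeared. Among the compounds with values here, no compound in the set carries a methyl on the sulfonyl phenyl, so the size of the effect for this group is open. A step to a lower number, smaller than the chloro step and beyond the scatter only at its upper end, is expected, a 3.3-fold lower number from compound 1 to compound 4 (0.52 log units; beyond the scatter). For compound 4 in this assay the estimate is 4500 nM, with a range from 1500 nM to 13000 nM.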

Compound 4, half-maximal inhibitory concentration: 1300 nM
For compound 4 the middle estimate is 3.5-fold (0.54 log units) above the measured one; the whole stated range lies above it.
By their numbers in this assay, from the lowest: compounds 4 and 3 (each within the scatter of the next); then compounds 2 and 1 (each within the scatter of the next).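

In this assay the lowering at this place on the sulfonyl phenyl no longer rests on chloro alone: methyl gives a 12-fold lower number from compound 1 to compound 4 (1.06 log units; beyond the scatter) as a large step, so a second group now shows it. Between the two groups, a 1.2-fold lower number from compound 3 to compound 4 (0.06 log units; within the scatter) gives no order, and at this level of the series methyl and chloro cannot be told apart at this place. The step of a 7.7-fold lower number from compound 2 to compound 4 (0.89 log units; beyond the scatter) extends the earlier contrast with compound 2 to a second group, so in these four compounds the lower numbers go with this place and not with the place of the chloro in compound 2; no information in hand bears on why the two groups match here.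

The compounds shown leave open how far this place tolerates change, since the only groups there are methyl and chloro, and a methoxy, an ethyl chain, an amine or a carboxylic acid could give a different picture. Also open, as far as these compounds go, is whether a methyl at the place of the chloro in compound 2 would stay as close to the unsubstituted compound 1 as that chloro does.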